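The compounds below may be only part of what the source reports. "The series", "measured", "known", "first", "only" and "open" are said of these compounds alone.

Compound 1, `Cc1cc(C)cc(CSc2nc(Cc3c(F)cccc3F)c(C)c(=O)[nH]2)c1`, has no exact reading in an ADME assay on MT4 cells (Homo sapiens) for cytotoxicity, read by MTT assay; on this read-out higher numbers stand for lower toxicity in this test and lower numbers for higher toxicity in this test. There compound 1 gives > 65000 nM, which is a limit and not a number. For the measured compounds named here, the only other compound measured, compound 2, `CCc1c(Cc2c(F)cccc2Cl)nc(SCC(=O)c2ccc(OC)cc2)[nH]c1=O`, is also known only by a limit, with compound 2 at > 11000 nM. Going by the values given here, no measured step between compounds that differ in one place is available, so the size of any structural effect in this assay remains open.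

The next compound is compound 3, `Cc1c(Cc2c(F)cccc2F)nc(SCC(=O)c2ccc(F)cc2)[nH]c1=O`. It carries (4-fluorophenyl)carbonyl in place of 3,5-dimethylphenyl on a saturated chain carbon bound to a sulfur. A modest move toward lower numbers is expected, and the estimated change is an at least 2.1-fold lower number from compound 1 to compound 3 (0.33 log units; beyond the scatter). This expectation rests on two limits alone, so it is loose, and compound 3 may well be reported only as a limit too. Compound 3 is estimated at 30000 nM, with the expected range running from 8000 nM to 120000 nM.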

Compound 3, half-maximal cytotoxic concentration: > 62000 nM
Compound 3: only a limit was reported; the forecaster's own chance of this, stated with the estimate: 60%; middle value at least 2.0-fold (0.31 log units) from the limit.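

In this assay compound 3 gives > 62000 nM, which is a limit and not a number. Compound 1 is also known only by a limit, and the step between compound 1 and compound 3 cannot be read. The compounds shown leave open whether (4-fluorophenyl)carbonyl in place of 3,5-dimethylphenyl changes the half-maximal cytotoxic concentration at all.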